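Aryl substituent swap on the sulfonyl amidine series

This account rests on a few compounds, and the source may have more. Where it says the series, first, only, none or still open, it means among the compounds named here.

Compound 2 `Cc1ccc(S(=O)(=O)/N=C(/CCNC2=CC(=O)c3ccccc3C2=O)Nc2ccccc2I)cc1` is the higher of the two numbers measured in a functional assay on MCF7 cells (Homo sapiens) for cytotoxicity, read by MTT assay, with a stated time of 48 h (a higher number here means a weaker inhibitor, a lower number a stronger inhibitor), so far; compound 2 gives 15500 nM, while compound 1 `Cc1ccc(S(=O)(=O)/N=C(/CCNC2=CC(=O)c3ccccc3C2=O)Nc2ccccc2[N+](=O)[O-])cc1` gives 3090 nM. Within the data shown here, the only step measured, a 5.0-fold higher number from compound 1 to compound 2 (0.70 log units; beyond the scatter), changes one substituent on the aryl ring attached to the amine nitrogen and moves the number modestly. Compound 3 `COc1ccc(N/C(CCNC2=CC(=O)c3ccccc3C2=O)=N\S(=O)(=O)c2ccc(C)cc2)cc1OC` differs from compound 2 by 3,4-dimethoxyphenyl in place of 2-iodophenyl on an amine nitrogen. Among the measured compounds shown here, no measured step bears directly on this change; the step from compound 1 to compound 2 shows only that altering this aryl group can shift the number beyond the scatter in either direction. The expectation for compound 3 in this assay is therefore a step of uncertain direction, set as a 1.9-fold lower number from compound 2 to compound 3 (0.29 log units; within the scatter). The estimate for compound 3 is 8000 nM, within a range from 2500 nM to 25000 nM.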

Compound 3, half-maximal inhibitory concentration: 12300 nM
Estimate against measurement, compound 3: 1.5-fold (0.19 log units) below; measured number inside the range.
By their numbers in this assay, from the lowest: compound 1; then compounds 3 and 2 (each within the scatter of the next).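

In this assay the step to the larger 3,4-dimethoxyphenyl, which brings two oxygens and two hydrogen-bond acceptors, is a 1.3-fold lower number from compound 2 to compound 3 (0.10 log units; within the scatter) and so does not separate it from 2-iodophenyl on this amine nitrogen. Among these compounds, the second reading, a 4.0-fold higher number from compound 1 to compound 3 (0.60 log units; beyond the scatter) and beyond the scatter, matches the earlier step from the nitro compound and leaves 2-nitrophenyl as the one aryl group of the three set apart from the other two. No measurement at hand gives a reason for these numbers. On these data alone, whether that separation belongs to the nitro group itself or to the 2-nitrophenyl arrangement stays open. An unsubstituted phenyl or a 4-nitrophenyl on the same nitrogen would bear directly on that question.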